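The source may hold more compounds than are shown below. What is called first, only, known or untested is meant among the compounds shown, and "the series" means these compounds.

In an ADME assay on J774.1 cells (Mus musculus) for cytotoxicity, read by MTT assay, with a stated time of 48 h (on this read-out higher numbers stand for weaker inhibition and lower numbers for stronger inhibition), compound 1 `Cc1c(C(=O)N/N=C/c2ccccc2)no[n+]1[O-]` shows only a limit of the assay, > 400000 nM.
Compound 2 `COc1ccc(/C=N/NC(=O)c2no[n+]([O-])c2C)cc1OC` likewise reaches only a limit, > 400000 nM.
Compound 3 `Cc1c(C(=O)N/N=C/c2cccc(O)c2)no[n+]1[O-]` also stops at a limit, > 400000 nM.

Compound 3 therefore stands at the limit, together with every other measured compound (the limit of > 400000 nM in this assay, at which 3 of the 3 values shown sit). Among the measured compounds shown here, the only step between measured compounds that differ in one place, a step that the two limits leave unreadable from compound 1 to compound 3, lies between two limits and cannot be read. Compound 4 `COc1ccc(/C=N/NC(=O)c2no[n+]([O-])c2C)cc1O` is the next compound: methoxy in place of hydrogen on an aromatic carbon. For the measured compounds named here, no measured step bears on this change with a readable size. The step that the limit leaves unreadable from compound 3 to compound 4 is expected to show no change beyond the scatter in this assay, with compound 4 most probably reported again as a limit. Compound 4 is estimated at 500000 nM, with a range from 150000 nM to 2000000 nM.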

Compound 4, half-maximal inhibitory concentration: > 400000 nM
Compound 4: only a limit was reported; the forecaster's own chance of this, stated with the estimate: 85%; the middle value is on the limit's open side.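

Compound 4 also gives only a limit, so neither its step from compound 2 nor its step from compound 3 can be read: the limit of > 400000 nM in this assay, at which 4 of the 4 values shown sit. The compounds shown leave open which structural change, if any, would give a readable value in this assay.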